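Thiophen-2-yl in place of furan-2-yl

The source may hold more compounds than are shown below. What is called first, only, known or untested is meant among the compounds shown, and "the series" means these compounds.

In a functional assay on T47D cells (Homo sapiens) for inhibition, read by CCK-8 assay and cell counting, with a stated time of 2 days (a higher number here means a weaker inhibitor, a lower number a stronger inhibitor), compound 1 (`O=C(/C=C/c1ccco1)c1ccccc1OCC1CO1`) gives 19400 nM and compound 2 (`O=C(/C=C/c1ccco1)c1cccc(OCC2CO2)c1`) gives 22700 nM while compound 3 (`O=C(/C=C/c1ccco1)c1ccc(OCC2CO2)cc1`) gives 17700 nM on the same read-out. Compound 3 stands within the scatter of both other compounds, so the three values set up no order. Compound 4 (`O=C(/C=C/c1cccs1)c1ccc(OCC2CO2)cc1`) carries thiophen-2-yl in place of furan-2-yl on a double-bonded chain carbon bound to a double-bonded chain carbon. Within the data shown here, no measured pair shows this kind of change, so the data give no size for it. In this assay no step beyond the scatter is expected. The estimated change is a 1.1-fold lower number from compound 3 to compound 4 (0.04 log units; within the scatter) and no more. In this assay the estimate for compound 4 is 16000 nM with an expected range from 7500 nM to 32000 nM for this measurement.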

Compound 4, half-maximal inhibitory concentration: 17800 nM
Beside the measured number, compound 4's estimate is 1.1-fold (0.05 log units) below it; low and high end bracket the measured number.
By their numbers in this assay, from the lowest: compounds 3, 4, 1 and 2 (each within the scatter of the next).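

Thiophen-2-yl in place of furan-2-yl on a double-bonded chain carbon bound to a double-bonded chain carbon gives a 1.0-fold higher number from compound 3 to compound 4 (0.00 log units; within the scatter) in this assay. Among these compounds, this is the first measured size for a change at this place, as compounds 1, 2 and 3 all carry furan-2-yl there. No available data bear on why the two rings read alike. On these data alone, whether the same replacement holds on the cores of compound 1 and compound 2 remains open. So does the effect of an amine or a carboxylic acid in place of the ring.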